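A few compounds are considered here, and "the series" means these few. Any claim that something is new, unique, unknown or untested is made for them only; others in the source may bear on it.

Compound 1 `O=C(Nc1cc(C(F)(F)F)cc(C(F)(F)F)c1)c1cc(Cl)c(F)cc1O` gives 430 nM
Compound 2 `Cc1ccc(C(=O)Nc2ccc(C#N)cc2)c(O)c1` gives 2420 nM

Both numbers come from a functional assay on HL-60 cells (Homo sapiens) for cytotoxicity, read by luminescence and CellTiter-Glo, with a stated time of 3 days (a lower number here means a stronger inhibitor, a higher number a weaker inhibitor), and lie further apart than the usual scatter. Compound 2 has the higher number of the two, which makes it the weaker inhibitor here. Compound 1 and compound 2 differ in more than one place, so this pair says nothing about the effect of a single change.

Compound 3 `COc1ccc(C(=O)Nc2ccc(C#N)cc2)c(O)c1` otherwise matches compound 2 but has methoxy in place of methyl on an aromatic carbon, meta to a hydroxy group and para to a large group (methoxy in place of methyl on an aromatic carbon). Among the compounds with values here, no measured pair shows this swap, so no step beyond the scatter is expected in this assay and neither direction is favoured. The expected change is a 1.1-fold lower number from compound 2 to compound 3 (0.02 log units; within the scatter) by this estimate. For compound 3 the estimated value is 2300 nM with an expected range of 900 nM to 6000 nM around it.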

Compound 3, half-maximal inhibitory concentration: 5470 nM
The estimate for compound 3 lay 2.4-fold (0.38 log units) below the measured number; the range from low to high includes it.
By their numbers in this assay, from the lowest: compound 1; then compound 2; then compound 3.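

In this assay, methoxy in place of methyl on this aromatic carbon, meta to a hydroxy group and para to a large group, gives a 2.3-fold higher number from compound 2 to compound 3 (0.35 log units; beyond the scatter). This is the only pair shown that differs in one place, so it is the only direct reading of a single change, and it shows that this position is sensitive to the swap, with a modest step that lies beyond the usual scatter. Nothing measured here explains why the number rises.

The compounds shown leave open whether an amine or a longer chain such as ethyl at this position would give a lower or a higher number than methyl. They also leave open whether the same swap would give a similar step on a different core, such as the core of compound 1.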